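Piperidine for oxane at the bicyclic core: clearance outlook

The compounds below may be only part of what the source reports. "The series", "measured", "known", "first", "only" and "open" are said of these compounds alone.

Three compounds carry numbers in an ADME assay on microsomes from liver (Homo sapiens) for metabolic stability; on this read-out higher numbers stand for fast clearance and lower numbers for slow clearance. Compound 3 `COc1cc(C(=O)N2CCCC2)ccc1-c1ccnc2[nH]c(C3CCOCC3)cc12` stands highest of the two numbers shown, giving 74 uL/min in this assay. Compound 1 `CNC(=O)CN1CCC(c2cc3c(-c4ccc(=O)n(C(C)C)c4)ccnc3[nH]2)CC1` gives 8.6 uL/min in this assay. Compound 2 `CC(=O)N1CCC(c2cc3c(-c4ccc(=O)n(C(C)C)c4)ccnc3[nH]2)CC1` gives only a limit in this assay, < 3 uL/min, which is the limit of < 3 uL/min in this assay, at which 1 of the 3 values shown sits. Among the measured compounds shown here, the single measured step, an at least 2.8-fold lower number from compound 1 to compound 2 (0.45 log units; beyond the scatter), concerns a group on a ring amine nitrogen of a different core and does not cover the change now in view.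

Compound 4 `COc1cc(C(=O)N2CCCC2)ccc1-c1ccnc2[nH]c(C3CCNCC3)cc12` differs from compound 3 in one place: piperidin-4-yl in place of oxan-4-yl on an aromatic carbon. For the measured compounds named here, no measured step bears directly on this change, so the expectation rests only on the level of compound 3 and on the lower values of compounds 1 and 2, which share a piperidine ring but differ from compound 4 in several other places. A moderate fall is expected, a 2.5-fold lower number from compound 3 to compound 4 (0.39 log units; beyond the scatter). Compound 4 is therefore estimated at 30 uL/min in this assay, within a range of 10 uL/min to 90 uL/min.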

Compound 4, intrinsic clearance in a liver preparation (reported as CLH), per the amount of preparation that the assay uses in the Homo sapiens assay: < 3 uL/min
Compound 4 gave a limit, no number; the forecaster's own chance of this, stated with the estimate: 5%; middle value at least 10-fold (1.00 log units) from the limit.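

In the Homo sapiens assay, piperidin-4-yl in place of oxan-4-yl on this aromatic carbon gives an at least 24-fold lower number from compound 3 to compound 4 (1.39 log units; beyond the scatter); compound 4 stands at a limit of the assay, so this step is a bound and not a measured size. In a physicochemical assay for lipophilicity, using the shake flask method, measured as octanol-water partition, at pH 7.4 (on this read-out higher numbers stand for higher lipophilicity and lower numbers for lower lipophilicity), compound 3 gives 3, and compound 4 gives 0.1. Lower lipophilicity is a possible reason for the clearance fall at this position, because the same change also shifts the partition read-out: the measured distribution coefficient of compound 3, 3, and of compound 4, 0.1, a number 2.90 log units lower (beyond the scatter)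

On these data alone, how far clearance falls with this change stays unresolved, because compound 4 gives no number: the limit of < 3 uL/min in the Homo sapiens assay, at which 2 of the 4 values shown sit. Also open is whether a carboxylic acid or an N-methylpiperidin-4-yl group at this position would keep clearance this low, and whether the two read-outs can move apart, which a single pair cannot tell.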